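Swapping the Formylphenyl Arm for a Naphthalenyl Group

The compounds below may be only part of what the source reports. "The series", "measured", "known", "first", "only" and "open" are said of these compounds alone.

Compound 3 `O=Cc1ccc(-c2cn3ccnc3c(-c3ccc4ncn(Cc5ccccc5)c4c3)n2)cc1` carries a 4-formylphenyl group on the shared core. In a functional assay on MOLT-4 cells (Homo sapiens) for inhibition, read by sulforhodamine B assay, with a stated time of 48 h, tested at 10 uM (a lower number here means less inhibition, a higher number more inhibition at the concentration tested (going by the name of the read-out)), compound 3 gives 58.7%. Within the data shown here, that is the highest of the three numbers measured so far, although its nearest neighbour, compound 2 `CCc1ccc(-c2cn3ccnc3c(-c3ccc4ncn(Cc5ccccc5)c4c3)n2)cc1`, which gives 54.2%, sits within the usual scatter of it: the step of a number 4.5 percentage points higher from compound 2 to compound 3 (within the scatter) is too small to count as a difference. Compound 1 `c1ccc2c(-c3cn4ccnc4c(-c4ccc5ncn(C6CCCCC6)c5c4)n3)cccc2c1`, which already carries a naphthalen-1-yl group but a cyclohexyl rather than a benzyl group elsewhere on the core, gives 44.7%, a number that lies beyond the scatter below compound 3.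

Compound 4 `c1ccc(Cn2cnc3ccc(-c4nc(-c5cccc6ccccc56)cn5ccnc45)cc32)cc1` differs from compound 3 in a single place: naphthalen-1-yl in place of 4-formylphenyl on an aromatic carbon. Among the measured compounds shown here, no measured step covers exactly this exchange. The step from compound 2 to compound 3 shows that altering the group on the phenyl ring moved the read-out only within the scatter, while compound 1 shows that a compound bearing naphthalen-1-yl can give a clearly lower number, though it also differs in a second place. A modest drop is therefore expected, a number 10.7 percentage points lower from compound 3 to compound 4 (beyond the scatter), with wide uncertainty. Compound 4 is estimated at 48%, expected to fall between 30% and 66%.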

Compound 4, a percentage reported as inhibition, at one concentration (the size of the read-out at that concentration, not a potency): 22.3%
Compound 4: middle estimate off by 25.7 percentage points, on the high side, outside the stated range (below it).
By their numbers in this assay, from the lowest: compound 4; then compounds 1, 2 and 3 (each within the scatter of the next, the first and the last beyond it).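

In this assay, among these compounds, the step of a number 36.4 percentage points lower from compound 3 to compound 4 (beyond the scatter) and the step of a number 31.9 percentage points lower from compound 2 to compound 4 (beyond the scatter) are both large, while changing ethyl to formyl on the phenyl ring gave only the step of a number 4.5 percentage points higher from compound 2 to compound 3 (within the scatter). At this aromatic carbon of the shared core, replacing the whole substituted phenyl group with naphthalen-1-yl therefore matters far more than the exchange on the phenyl ring among these compounds. Naphthalen-1-yl does not set the number on its own, as benzyl in place of cyclohexyl on the aromatic nitrogen gives the step of a number 22.4 percentage points lower from compound 1 to compound 4 (beyond the scatter), and no accompanying measurement accounts for either drop.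

The compounds shown leave open whether a plain phenyl ring, or a phenyl ring carrying an amine or a carboxylic acid in place of formyl, would give a number close to that of compound 3 or to that of compound 4. They also leave open how 4-formylphenyl behaves with cyclohexyl on the aromatic nitrogen, so the two places cannot yet be judged separately.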